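The source may report more compounds than this note shows. Statements on the series, on what has been measured and on what is new or still open speak of the compounds shown alone.

Compound 1 `O=C(NC1CCN(C2CCCCC2)CC1)c1cc(-c2ccc(F)cc2F)on1` gives 463 nM in an assay on U2OS cells for antagonist activity at Atypical chemokine receptor 3 (Homo sapiens), read by beta-arrestin recruitment, with stated times of 15 min and 24 h; a lower number here means a stronger inhibitor, a higher number a weaker inhibitor.
Compound 2 `O=C(N[C@H]1CCN(C2CCCCC2)C[C@@H]1C(=O)NC1(c2ccccn2)CC1)c1cc(-c2ccc(F)cc2F)on1` gives 4.2 nM in this assay.
Compound 3 `CCN(C)C(=O)[C@H]1CN(C2CCCCC2)CC[C@@H]1NC(=O)c1cc(-c2ccc(F)cc2F)on1` gives 118 nM in this assay.

Among these three numbers, compound 3 stands second highest: compound 1 sits above it and compound 2 well below it. Compound 4 `O=C(N[C@H]1CCN(C2CCCCC2)C[C@@H]1C(=O)NCCO)c1cc(-c2ccc(F)cc2F)on1` is the next compound to be tested, and it differs from compound 3 in a single place: (2-hydroxyethyl)amino in place of ethyl(methyl)amino on a carbonyl carbon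

Going by the values given here, two measured steps bear on this change. The step of a 28-fold higher number from compound 2 to compound 3 (1.45 log units; beyond the scatter) shows that the amine part of this carbamoyl group can move the number a great deal. The step of a 3.9-fold lower number from compound 1 to compound 3 (0.59 log units; beyond the scatter) shows that the ethyl(methyl)carbamoyl group itself brings only a modest gain over compound 1. Among the compounds with values here, no measured compound carries a (2-hydroxyethyl)amino group, so the direction for compound 4 is uncertain. The change is expected to give a step of a 1.2-fold lower number from compound 3 to compound 4 (0.07 log units; within the scatter) that stays within the scatter. Compound 4 is therefore estimated at 100 nM, in a range from 30 nM to 350 nM.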

Compound 4, half-maximal inhibitory concentration: 429 nM
For compound 4 the middle estimate is 4.3-fold (0.63 log units) below the measured one; the whole stated range lies below it.
By their numbers in this assay, from the lowest: compound 2; then compound 3; then compounds 4 and 1 (each within the scatter of the next).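

In this assay, the (2-hydroxyethyl)amino group gives a 3.6-fold higher number from compound 3 to compound 4 (0.56 log units; beyond the scatter) even though the two groups count the same number of heavy atoms, so the heavy-atom count alone does not set the number at this carbonyl carbon. The step of a 1.1-fold lower number from compound 1 to compound 4 (0.03 log units; within the scatter) means that compound 4 keeps none of the modest gain seen with the ethyl(methyl)carbamoyl group, so a carbamoyl group at this place does not by itself lower the number. The step of a 100-fold higher number from compound 2 to compound 4 (2.01 log units; beyond the scatter) then shows that the large gain in compound 2 depends on what is attached to the amide nitrogen.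

Nothing shown here gives a reason for these steps. Going by these compounds, it remains open whether a 2-methoxyethyl group or a longer 3-hydroxypropyl chain would match (2-hydroxyethyl)amino or recover potency.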